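The source may report more compounds than this note shows. Statements on the series, on what has been measured and on what is new or still open speak of the compounds shown alone.

Measured compounds:
compound 1, `O=C(Nc1ccc(Oc2ccc(-c3nccs3)cc2)cc1)Nc1ccc(Cl)c([N+](=O)[O-])c1`, gives 72.8% in a functional assay on MDA-MB-231 cells (Homo sapiens) for inhibition, read by MTT assay and WST assay, with a stated time of 72 h, tested at 10 uM; a higher number here means more inhibition of growth at the concentration tested, a lower number less inhibition of growth
compound 2, `O=C(Nc1ccc(Oc2ccc(-c3ncc[nH]3)cc2)cc1)Nc1ccc(Cl)c([N+](=O)[O-])c1`, gives 3.36%

Going by the values given here, compound 2 stands lowest of the two numbers in this assay; its nearest neighbour is compound 1, and the only measured step, a number 69.4 percentage points lower from compound 1 to compound 2 (beyond the scatter), lies between them. That step concerns the exchange of the five-membered ring and bears on nothing else.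

Compound 3, `O=C(Nc1ccc(Oc2ccc(-c3ncc[nH]3)cc2)cc1)Nc1ccc(F)c(Cl)c1`, differs from compound 2 at another place: 3-chloro-4-fluorophenyl in place of 4-chloro-3-nitrophenyl on an amide-type nitrogen. Among the compounds with values here, no measured step covers this kind of change, so the one known step gives no guidance, and the effect of the new group on the shared core is unknown. Since compound 2 is already low, the most cautious expectation is no step beyond the scatter, with room for a modest rise.

Compound 3 is therefore estimated at 10%, within 0% to 40%, which means an expected step of a number 6.6 percentage points higher from compound 2 to compound 3 (within the scatter).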

Compound 3, percent growth inhibition at one concentration: 4.2%
Compound 3: middle estimate off by 5.8 percentage points, on the high side; the range from low to high includes it.
By their numbers in this assay, from the lowest: compounds 2 and 3 (each within the scatter of the next); then compound 1.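

With the 1H-imidazol-2-yl group held constant, placing 3-chloro-4-fluorophenyl instead of 4-chloro-3-nitrophenyl on the amide-type nitrogen gives a number 0.8 percentage points higher from compound 2 to compound 3 (within the scatter) in this assay. Going by these compounds alone, this is the first measured change at this position, and it shows that this exchange does not bring back the growth inhibition seen with compound 1, as the two numbers cannot be told apart from the scatter. No measured information explains this result.

The compounds shown leave open whether the same exchange would also make no clear difference on the core of compound 1, which carries the 1,3-thiazol-2-yl group. They also leave open how this position would respond to a more different group on the same nitrogen, such as a phenyl ring carrying a carboxylic acid or a dimethylamino group.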